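The source may hold more compounds than are shown below. What is called first, only, known or untested is meant among the compounds shown, and "the series" means these compounds.

Measured in a functional assay on HT-29 cells (Homo sapiens) for cytotoxicity, read by MTT assay, with a stated time of 72 h; a lower number here means a stronger inhibitor of growth, a higher number a weaker inhibitor of growth: compound 1 `O=C(/N=C(/NC(=O)c1cccs1)[Se]Cc1ccccc1)c1cccs1` gives 55100 nM, and compound 2 `CS/C(=N\C(=O)c1cccs1)NC(=O)c1cccs1` gives 77900 nM. Compound 3 `CS/C(=N\C(=O)c1cnc2ccccc2c1)NC(=O)c1cnc2ccccc2c1` reaches only a limit of the assay, > 100000 nM, which is the limit of > 100000 nM in this assay, at which 1 of the 3 values shown sits.

The change from compound 2 to compound 1 is a group of 8 heavy atoms (7 carbon, 1 selenium; one six-membered aromatic ring of carbon only) in place of a group of 2 heavy atoms (1 carbon, 1 sulfur; no ring), on a carbon with a double bond to nitrogen. The step it made was a 1.4-fold lower number from compound 2 to compound 1 (0.15 log units; within the scatter). How the core of compound 3 differs from the core of compound 2 is not broken down here. Compound 4 `O=C(/N=C(/NC(=O)c1cnc2ccccc2c1)[Se]Cc1ccccc1)c1cnc2ccccc2c1` is the unmeasured partner of compound 3: a group of 8 heavy atoms (7 carbon, 1 selenium; one six-membered aromatic ring of carbon only) in place of a group of 2 heavy atoms (1 carbon, 1 sulfur; no ring), on a carbon with a double bond to nitrogen, the same change at the same place. Because the earlier step of a 1.4-fold lower number from compound 2 to compound 1 (0.15 log units; within the scatter) stayed within the scatter, the same is expected here. Compound 3 sits at a limit, > 100000 nM, so a limit again is quite likely. The expected step to compound 4 is a number no higher from compound 3 to compound 4 (the limit leaves the size open). Compound 4 is estimated at 100000 nM, expected between 45000 nM and 300000 nM.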

Compound 4, concentration for 50% growth inhibition: 26100 nM
Estimate against measurement, compound 4: 3.8-fold (0.58 log units) above; the whole stated range lies above it.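

In this assay, putting the selenium-containing group with its six-membered aromatic ring in place of methylsulfanyl gives an at least 3.8-fold lower number from compound 3 to compound 4 (0.58 log units; beyond the scatter). Going by these compounds, the same change therefore does not carry over from one core to the other with the same size: the same change on two cores in this assay, a 1.4-fold lower number (0.15 log units; within the scatter) from compound 2 to compound 1 and an at least 3.8-fold lower number (0.58 log units; beyond the scatter) from compound 3 to compound 4, at least 2.7-fold (0.43 log units) apart, beyond the scatter of two such steps Compound 3 stands at a limit of the assay, so the full size of its step stays unknown, and two cores alone do not show which difference between them matters or what a third core would do.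

The entering group differs from methylsulfanyl in both its selenium and its aromatic ring, and the compounds shown leave open which of these goes with the lower number. A benzylsulfanyl or a methylselanyl group on the same carbon would separate the two.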